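The source may hold more compounds than are shown below. What is called first, only, known or untested is meant among the compounds shown, and "the series" means these compounds.

Series notes, step from compound 3 to compound 4.

Compound 3 is `O=C(Nc1ccc(Cl)c(-c2nnc3c(Cl)cccn23)c1)c1c(F)cccc1Cl`. In a functional assay on MCF7 cells (Homo sapiens) for antiproliferative activity, read by MTT assay, with a stated time of 72 h (on this read-out higher numbers stand for weaker inhibition and lower numbers for stronger inhibition), compound 3 gives > 100000 nM, which is a limit of the assay and not a number. The series holds two neighbours with the same core. Compound 1 is `O=C(Nc1ccc(Cl)c(-c2nnc3c(Cl)cccn23)c1)c1ccccn1` and in this assay compound 1 gives 96400 nM. Compound 2 is `Cc1cc(Cl)ccc1C(=O)Nc1ccc(Cl)c(-c2nnc3c(Cl)cccn23)c1`. In this assay compound 2 gives > 100000 nM, again a limit and not a number; see (the limit of > 100000 nM in this assay, at which 2 of the 3 values shown sit). The measured steps are an at least 1.0-fold higher number from compound 1 to compound 2 (0.01 log units; that floor lies within the scatter) and an at least 1.0-fold higher number from compound 1 to compound 3 (0.01 log units; that floor lies within the scatter), both of them with a floor inside the scatter, while a step that the two limits leave unreadable from compound 2 to compound 3 cannot be sized from two limits.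

Compound 4 is `O=C(Nc1ccc(Cl)c(-c2nnc3c(Cl)cccn23)c1)c1ccccc1`, obtained from compound 3 by phenyl in place of 2-chloro-6-fluorophenyl on a carbonyl carbon. All three measured amides sit at or close to the limit, so the exchange of aryl groups on the carbonyl carbon has produced no readable step; for compound 4 no step beyond the scatter is expected in this assay, that is a number no higher from compound 3 to compound 4 (the limit leaves the size open). The estimate for compound 4 is 100000 nM, expected between 40000 nM and 300000 nM.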

Compound 4, half-maximal inhibitory concentration: > 100000 nM
Compound 4: no number, only a limit; the forecaster's own chance of this, stated with the estimate: 55%; the middle value lies on the limit itself.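

Compound 4 gives > 100000 nM in this assay, which is a limit of the assay and not a number. The bare phenyl therefore adds nothing readable to the picture: with no substituent on the ring, the amide stays at the same limit as those bearing 2-chloro-6-fluorophenyl and 4-chloro-2-methylphenyl, and the steps to compound 4 from compound 2 and compound 3 cannot be read. The only readable step is an at least 1.0-fold higher number from compound 1 to compound 4 (0.01 log units; that floor lies within the scatter), and the series now gathers at a single ceiling: the limit of > 100000 nM in this assay, at which 3 of the 4 values shown sit.

It remains open whether any group on this carbonyl carbon can give a value clearly clear of that limit, since the compounds shown carry only aromatic rings there. An aliphatic amine, a carboxylic acid or a longer chain in that place would test this.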